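The source may report more compounds than this note shows. Statements on the series, on what has been measured and on what is new or still open speak of the compounds shown alone.

In a functional assay on HepG2 cells (Homo sapiens) for cytotoxicity, read by MTT assay, with a stated time of 48 h (a lower number here means a stronger inhibitor, a higher number a weaker inhibitor), compound 1 `CC(=O)OC[C@H]1O[C@H](NS(N)(=O)=O)C=C[C@@H]1OC(C)=O` gives 336000000 nM. Compound 2 `CC(=O)OC[C@H]1O[C@H](NS(N)(=O)=O)C=C[C@H]1OC(C)=O` shares every atom and bond with compound 1 and differs only in configuration as drawn; in this assay compound 2 gives 304000000 nM. The step of a 1.1-fold lower number from compound 1 to compound 2 (0.04 log units; within the scatter) is within the scatter, so the two numbers cannot be told apart, and compound 1 standing at one end of this pair carries no weight, since the fact that compounds 1 and 2 differ only in the configuration as drawn is all that separates them. Compound 3 `CCS(=O)(=O)N[C@@H]1C=C[C@H](OC(C)=O)[C@@H](COC(C)=O)O1` has not been measured. It differs from compound 1 by ethyl in place of amino on a sulfonyl sulfur. No measured step touches a change of this kind: the one step shown alters configuration, not the sulfonyl sulfur. The expectation therefore rests on compound 1 alone, and the step of no change at the digits printed from compound 1 to compound 3 (within the scatter) is estimated at no size beyond the scatter. Compound 3 is expected to give 336000000 nM, with a range from 100000000 nM to 1000000000 nM.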

Compound 3, half-maximal inhibitory concentration: 231000000 nM
The estimate for compound 3 lay 1.5-fold (0.16 log units) above the measured number; low and high end bracket the measured number.
By their numbers in this assay, from the lowest: compounds 3, 2 and 1 (each within the scatter of the next).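

In this assay, ethyl in place of amino on a sulfonyl sulfur gives a 1.5-fold lower number from compound 1 to compound 3 (0.16 log units; within the scatter). Where the earlier pair spoke only to configuration, this is the first reading of a change to the group itself: amino brings a hydrogen-bond donor and ethyl brings none, yet this difference leaves the two numbers indistinguishable. Nothing measured here speaks to the reason for this result.

Going by these compounds, it remains open whether a longer chain such as butyl, or a phenyl group, on the same sulfonyl sulfur would also stay within the scatter of compound 1. On these data alone, it is equally open whether a change elsewhere on the shared core, such as a free hydroxyl group in place of an acetate, would move the number.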